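Replacing trifluoromethyl with ethyl in compound 3

A few compounds are considered here, and "the series" means these few. Any claim that something is new, unique, unknown or untested is made for them only; others in the source may bear on it.

Compound 3 `CC(C)c1ccc(OC(C)(Cc2ccc(C(F)(F)F)cc2)C(=O)O)cc1` has no exact number in a functional assay on the whole organism for inhibition, with Rattus norvegicus as the target; on this read-out lower numbers stand for an effect already at smaller amounts and higher numbers for an effect only at larger amounts of compound. Compound 3 reads < 5 mg/kg, which is a limit of the assay. Its close relative, compound 1 `CC(C)c1ccc(OC(Cc2ccc(C(F)(F)F)cc2)C(=O)O)cc1`, gives 10 mg/kg. The methyl that separates them gives an at least 2.0-fold lower number from compound 1 to compound 3 (0.30 log units; that floor lies within the scatter), and that floor lies within the scatter. Compound 2 `COc1ccc(CC(Oc2ccc(C(C)C)cc2)C(=O)O)cc1` reads > 50 mg/kg, which is also a limit.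

Compound 4 `CCc1ccc(CC(C)(Oc2ccc(C(C)C)cc2)C(=O)O)cc1` carries a single change from compound 3: ethyl in place of trifluoromethyl on an aromatic carbon, with ethyl in place of trifluoromethyl on an aromatic carbon. The closest evidence is a replacement of trifluoromethyl at the same place, an at least 5.0-fold higher number from compound 1 to compound 2 (0.69 log units; beyond the scatter), which lies beyond the scatter. That step brought in methoxy rather than ethyl, and it was measured without the added methyl, so it serves only as a guide. A move to a higher number of modest size is expected, estimated as an at least 2.4-fold higher number from compound 3 to compound 4 (0.38 log units; beyond the scatter). For compound 4 the estimated value is 12 mg/kg, with an expected range of 4 mg/kg to 40 mg/kg.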

Compound 4, dose for half-maximal effect: 0.1 mg/kg
The estimate for compound 4 lay 120-fold (2.08 log units) above the measured number, outside the stated range (below it).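

No step can be read from compound 3 to compound 4 in this assay. Compound 3 stands at a limit: the limit of < 5 mg/kg in this assay, at which 1 of the 4 values shown sits.

The compounds shown leave open how ethyl in place of trifluoromethyl on an aromatic carbon acts in the absence of the added methyl.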